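Cyanosulfanyl thiadiazolo-imidazole series: aryl swap at the ring carbon

A few compounds are considered here, and "the series" means these few. Any claim that something is new, unique, unknown or untested is made for them only; others in the source may bear on it.

Of the compounds shown here, two of the shared core have been measured. Compound 1 `Clc1ccc(Cc2nn3cc(-c4ccc(Cl)cc4Cl)nc3s2)cc1` was tested in an ADME assay on CCRF-CEM cells (Homo sapiens) for cytotoxicity, with a stated time of 72 h (on this read-out lower numbers stand for stronger inhibition and higher numbers for weaker inhibition), and the assay gives for compound 1 only > 250000 nM, which is a limit and not a number. Among the compounds with values here, compound 2 `COc1ccc(-c2nc3sc(Cc4ccc(Cl)cc4)nn3c2SC#N)cc1` carries a cyanosulfanyl group and a 4-methoxyphenyl on the core; in this assay compound 2 gives 10000 nM, the only number in the set, the other value being (the limit of > 250000 nM in this assay, at which 1 of the 2 values shown sits). Within the data shown here, compound 1 and compound 2 differ in more than one place, so their two values show no single step.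

Compound 3 `N#CSc1c(-c2ccc(Cl)cc2Cl)nc2sc(Cc3ccc(Cl)cc3)nn12` is not yet measured. It differs from compound 2 by 2,4-dichlorophenyl in place of 4-methoxyphenyl on an aromatic carbon, so that 2,4-dichlorophenyl takes the place of 4-methoxyphenyl on an aromatic carbon, while the cyanosulfanyl group stays. The same 2,4-dichlorophenyl is the aryl of compound 1, whose value is a limit, but that pairing is not a single step. The step of a 2.0-fold higher number from compound 2 to compound 3 (0.30 log units; within the scatter) is expected to be modest toward weaker inhibition, and compound 3 is estimated at 20000 nM, within 5000 nM to 100000 nM.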

Compound 3, half-maximal inhibitory concentration: 46000 nM
For compound 3 the middle estimate is 2.3-fold (0.36 log units) below the measured one, and the stated range covers the measured number.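

In this assay, 2,4-dichlorophenyl in place of 4-methoxyphenyl, with the cyanosulfanyl group kept, gives a 4.6-fold higher number from compound 2 to compound 3 (0.66 log units; beyond the scatter), so this position responds to the choice of aryl, and the change runs toward weaker inhibition. With the 2,4-dichlorophenyl held constant, cyanosulfanyl in place of hydrogen on an aromatic carbon gives an at least 5.4-fold lower number from compound 1 to compound 3 (0.73 log units; beyond the scatter), the first single step available for that group, and it runs toward stronger inhibition. The value of compound 1 is a limit and not a number, which leaves that step with one bound only: the limit of > 250000 nM in this assay, at which 1 of the 3 values shown sits.

The compounds shown leave open how a plain phenyl, a 4-chlorophenyl or a phenyl carrying an amine or a carboxylic acid would read at this position, and so whether one chlorine alone could account for the aryl step. They also leave open whether a nitrile or a methylsulfanyl group on the ring atom that now bears the cyanosulfanyl group would give a step of similar size.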